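The source may report more compounds than this note shows. Statements on the series, on what has been measured and on what is new or still open speak of the compounds shown alone.

In a functional assay on MDA-MB-231 cells (Homo sapiens) for inhibition, read by MTT assay, with a stated time of 72 h (a higher number here means a weaker inhibitor, a lower number a stronger inhibitor), compound 2 `CC(C)[C@H](NC(=O)c1cc(Cl)ccc1OCCCCNC(=O)OC(C)(C)C)C(=O)Nc1ccc([N+](=O)[O-])cc1Cl` gives > 10000 nM, which is a limit of the assay and not a number. Compound 1 `CC(C)[C@H](NC(=O)c1cc(Cl)ccc1OCCN)C(=O)Nc1ccc([N+](=O)[O-])cc1Cl` gives > 10000 nM, which is also a limit. The whole picture so far is the limit of > 10000 nM in this assay, at which 2 of the 2 values shown sit, so compound 2 offers no measured number to start from.

Compound 3 `CC(C)[C@H](NC(=O)c1cc(Cl)ccc1OCCCCN)C(=O)Nc1ccc([N+](=O)[O-])cc1Cl` differs from compound 2 by one change, hydrogen in place of tert-butoxycarbonyl on an amine nitrogen, which leaves an aminated chain end. Among the measured compounds shown here, the only measured step that bears on this is a step that the two limits leave unreadable from compound 1 to compound 2, and it has no readable size. It links a compound with a free amino group to one with a protected amine, so it is the nearest comparison available, yet it gives neither a size nor a direction.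

On this evidence, a number no higher from compound 2 to compound 3 (the limit leaves the size open) is the expected step, with no firm direction, and another limit is the likeliest report. Compound 3 is estimated at 10000 nM, with an expected range of 3000 nM to 30000 nM.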

Compound 3, half-maximal inhibitory concentration: 5590 nM
Beside the measured number, compound 3's estimate is 1.8-fold (0.25 log units) above it, within the range that was stated.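

In this assay compound 3 is the only one of the three compounds to give a measured number instead of a limit: the limit of > 10000 nM in this assay, at which 2 of the 3 values shown sit.

Replacing tert-butoxycarbonyl with hydrogen on the amine nitrogen gives an at least 1.7-fold lower number from compound 2 to compound 3 (0.25 log units; that floor lies within the scatter), and 2-aminoethyl in place of amino gives an at least 1.7-fold lower number from compound 1 to compound 3 (0.25 log units; that floor lies within the scatter); both figures are floors set by the limits of the starting compounds, and each floor lies within the scatter, so neither change can yet be given a size, while the step between the two limited compounds cannot be read at all. What the series does show is that, of the three, only the compound combining the longer chain with an uncapped amine at its end comes off the limit, whereas compound 1 has the free amine on the shorter chain and compound 2 has the longer chain with its amine capped.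

Going by these compounds, how far the two limited compounds really lie from compound 3 remains open. So does whether a still longer chain, a dimethylamine or a carboxylic acid at the chain end would move the number further in either direction.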